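Working notes: propyl extension on the core of compound 1

The source may report more compounds than this note shows. Statements on the series, on what has been measured and on what is new or still open speak of the compounds shown alone.

Measured so far:
compound 1 `Cc1cc2ccccc2nc1-c1cn(CCC(F)(F)C(F)(F)C(F)(F)C(F)(F)C(F)(F)C(F)(F)C(F)(F)C(F)(F)F)nn1` — 75.8 ug/mL
compound 2 `CCCCCCCCCCn1cc(-c2nc3ccccc3cc2CCC)nn1` — > 100 ug/mL
compound 3 `CCCc1cc2ccccc2nc1-c1cn(-c2ccc(F)cc2)nn1` — > 100 ug/mL

All three were tested in a functional assay on COLO 205 cells (Homo sapiens) for cytotoxicity, read by MTT assay, with a stated time of 24 h; a higher number here means a weaker inhibitor, a lower number a stronger inhibitor. Compound 1 carries the only numerical result: in this assay compound 1 gives 75.8 ug/mL. For compound 2 the result is a limit of the assay, > 100 ug/mL. For compound 3 the result is likewise a limit, > 100 ug/mL. Within the data shown here, the frame is set by the limit of > 100 ug/mL in this assay, at which 2 of the 3 values shown sit, so compound 1 stands as the single point against two limits, and no step between measured compounds can be read in isolation.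

Compound 4, `CCCCc1cc2ccccc2nc1-c1cn(CCC(F)(F)C(F)(F)C(F)(F)C(F)(F)C(F)(F)C(F)(F)C(F)(F)C(F)(F)F)nn1`, is not yet measured. It differs from compound 1 by propyl in place of hydrogen on a saturated chain carbon bound to an aromatic carbon, the same core and the same long fluorinated chain being retained. Among the measured compounds shown here, no measured pair isolates this change, so the expectation rests on compound 1 alone together with the observation that two of three values sit at the limit. The step is expected to be small, toward weaker inhibition, and possibly not beyond the usual scatter. For compound 4 the estimate is 95 ug/mL, with a range from 50 ug/mL to 200 ug/mL. The expected step is a 1.3-fold higher number from compound 1 to compound 4 (0.10 log units; within the scatter), and a limit rather than a number is a real possibility.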

Compound 4, half-maximal inhibitory concentration: > 100 ug/mL
Compound 4: a limit, no number; the forecaster's own chance of this, stated with the estimate: 55%; at least 1.0-fold (0.02 log units) between middle value and limit.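

In this assay compound 4 gives > 100 ug/mL, which is a limit of the assay and not a number. Among these compounds, this is the first pair that differs in one place, and propyl in place of hydrogen on a saturated chain carbon bound to an aromatic carbon gives an at least 1.3-fold higher number from compound 1 to compound 4 (0.12 log units; that floor lies within the scatter), so the change has a lower bound on its size but no measured size, and that bound does not separate it from repeat scatter. Compound 1 remains the only compound with a number, so the longer group at this place brings no measurable gain in the range of the assay, and the series is now framed mostly by: the limit of > 100 ug/mL in this assay, at which 3 of the 4 values shown sit.

The compounds shown leave open how far the step from compound 1 to compound 4 really extends, and whether a shorter chain such as ethyl at this place would still give a number rather than a limit. Also open, on these data alone, is whether an amine or a carboxylic acid on this chain carbon, with the core and the long fluorinated chain kept, would give a number clearly apart from that of compound 1.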